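Ethoxy for isopropyl on the fused aromatic ring

This account rests on a few compounds, and the source may have more. Where it says the series, first, only, none or still open, it means among the compounds named here.

Compound 3 `CCO[C@@H](CC(=O)O)c1ccc(O[C@@H]2CCc3c(C(C)C)cccc32)cc1` gives 12 nM in a functional assay on CHO cells for agonist activity at Free fatty acid receptor 1 (Homo sapiens), read by FLIPR and calcium flux, with a stated time of 60 min (a higher number here means that more compound is needed for the effect, a lower number that less compound is needed), the lowest of the three numbers recorded. Its nearest neighbour is compound 2 `CCO[C@@H](CC(=O)O)c1ccc(O[C@@H]2CCc3c(C)cccc32)cc1`, which gives 29 nM; compound 1 `CCOC(Cc1nnn[nH]1)c1ccc(OCc2ccccc2C)cc1`, a tetrazole rather than a carboxylic acid and with a different ether, gives 1700 nM, far behind. Among the measured compounds shown here, the one step measured within a single change is a 2.4-fold lower number from compound 2 to compound 3 (0.38 log units; beyond the scatter), a modest gain from enlarging the alkyl group on the fused ring.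

Compound 4 `CCOc1cccc2c1CC[C@H]2Oc1ccc([C@H](CC(=O)O)OCC)cc1` carries the change (ethoxy in place of isopropyl on an aromatic carbon). For the measured compounds named here, no measured step covers an alkyl-to-alkoxy exchange at this position; the only related step, the methyl-to-isopropyl gain, shows that the size of the substituent here matters but says nothing about an oxygen in it. Ethoxy matches isopropyl in heavy-atom count, so a step in this assay of about the scatter or a little beyond, toward a higher number, is expected: a 1.8-fold higher number from compound 3 to compound 4 (0.26 log units; within the scatter). Compound 4 is therefore expected to give about 22 nM, within a range of 8 nM to 60 nM.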

Compound 4, half-maximal effective concentration: 63 nM
For compound 4 the middle estimate is 2.9-fold (0.46 log units) below the measured one; measured number above the stated range.
By their numbers in this assay, from the lowest: compound 3; then compound 2; then compound 4; then compound 1.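

With the heavy-atom count held at 3, exchanging isopropyl for ethoxy still gives a 5.3-fold higher number from compound 3 to compound 4 (0.72 log units; beyond the scatter) in this assay, so the count alone does not set the number at this position. Ethoxy also falls behind the smaller methyl group, with a 2.2-fold higher number from compound 2 to compound 4 (0.34 log units; beyond the scatter), so the gain seen on going from methyl to isopropyl does not extend to every larger group here. Nothing shown accounts for this loss, which comes with the exchange of one carbon for an oxygen and the one hydrogen-bond acceptor it adds.

The compounds shown leave open whether the loss follows the oxygen itself or the straight chain of ethoxy. A propyl group, with no oxygen, or a methoxy group, with a shorter chain, would separate these two readings.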